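Adding a methyl to the bromophenyl amide

The compounds below may be only part of what the source reports. "The series", "measured", "known", "first", "only" and "open" are said of these compounds alone.

Compound 1, `O=C(COc1ccc(/C=C2\SC(=O)NC2=O)cc1)Nc1ccccc1`: > 100000 nM
Compound 2, `O=C(COc1ccc(/C=C2\SC(=O)NC2=O)cc1)Nc1ccc(Br)cc1`: 32100 nM

Of the compounds shown here, two have been measured in a functional assay on KB cells (Homo sapiens) for inhibition; a lower number here means a stronger inhibitor of growth, a higher number a weaker inhibitor of growth. Compound 1 reaches only a limit of this assay, > 100000 nM, which is not a number; it is the limit of > 100000 nM in this assay, at which 1 of the 2 values shown sits. For the measured compounds named here, compound 2 gives 32100 nM in this assay, and it is therefore the only compound with a number. The other value shown, that of compound 1, is a limit. Going by the values given here, the single measured step is an at least 3.1-fold lower number from compound 1 to compound 2 (0.49 log units; beyond the scatter), brought about by bromo in place of hydrogen on an aromatic carbon.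

Compound 3, `Cc1cc(Br)ccc1NC(=O)COc1ccc(/C=C2\SC(=O)NC2=O)cc1`, is not yet measured. It differs from compound 2 by methyl in place of hydrogen on an aromatic carbon. Among the compounds with values here, no measured step involves a methyl; the one step known concerns a bromo and so does not bear directly on this change. With nothing pointing either way, the expectation is a step within the scatter, a 1.3-fold lower number from compound 2 to compound 3 (0.11 log units; within the scatter), in this assay. Compound 3 is thus estimated at 25000 nM, with a range from 8000 nM to 80000 nM.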

Compound 3, concentration for 50% growth inhibition: > 100000 nM
Compound 3 gave a limit, no number; the forecaster's own chance of this, stated with the estimate: 15%; at least 4.0-fold (0.60 log units) between middle value and limit.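

In this assay, a methyl on the aromatic ring, ortho to a large group and meta to the bromo group, reverses the direction seen with the bromo alone: the change is an at least 3.1-fold higher number from compound 2 to compound 3 (0.49 log units; beyond the scatter). For the compounds shown here, one added carbon at this position is thus enough to leave compound 2 as the only compound here with a number, and the activity it shows does not survive this small change. The result for compound 3 is a limit of the assay and not a number, and it is the same limit that compound 1 reached, so the step between those two compounds cannot be read: the limit of > 100000 nM in this assay, at which 2 of the 3 values shown sit.

As far as these compounds go, it remains open whether a methyl at this position would have the same effect on the unsubstituted phenyl amide, without the bromo group. From the compounds shown here alone, it is also open whether the loss is particular to the methyl or would also appear with another group in its place, such as a fluoro, a hydroxyl or an amine, and how far compound 3 actually lies beyond its limit.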